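This account rests on a few compounds, and the source may have more. Where it says the series, first, only, none or still open, it means among the compounds named here.

In a functional assay on A549 cells (Homo sapiens) for antiproliferative activity, read by MTT assay, with a stated time of 72 h (a higher number here means a weaker inhibitor, a lower number a stronger inhibitor), compound 1 `O=C(Nc1ccc(Oc2ccnc3[nH]ccc23)c(F)c1)c1cc2cccnc2n(-c2ccc(F)cc2)c1=O` gives 62 nM, and compound 2 `O=C(Nc1ccc(Oc2ccnc3[nH]ccc23)c(F)c1)c1cc2cccnc2n(-c2ccc(Br)cc2F)c1=O` gives 460 nM. Among the measured compounds shown here, of these two numbers compound 2 has the higher one, and the single measured step, a 7.4-fold higher number from compound 1 to compound 2 (0.87 log units; beyond the scatter), ran in that direction. Compound 3 `O=C(Nc1ccc(Oc2ccnc3[nH]ccc23)c(F)c1)c1cc2cccnc2n(-c2ccc(C(F)(F)F)cc2Cl)c1=O` carries 2-chloro-4-(trifluoromethyl)phenyl in place of 4-bromo-2-fluorophenyl on an aromatic nitrogen. For the measured compounds named here, only that one step bears on this change, and it concerns the same aromatic nitrogen, so the expected step from compound 2 is a 1.6-fold higher number from compound 2 to compound 3 (0.21 log units; within the scatter), most likely upward or within the scatter. Compound 3 is therefore estimated at 750 nM, with a range from 200 nM to 2800 nM.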

Compound 3, half-maximal inhibitory concentration: 1020 nM
The estimate for compound 3 lay 1.4-fold (0.13 log units) below the measured number; measured number inside the range.
By their numbers in this assay, from the lowest: compound 1; then compound 2; then compound 3.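

In this assay, the group on the aromatic nitrogen still matters beyond the first change: 2-chloro-4-(trifluoromethyl)phenyl is weaker than 4-bromo-2-fluorophenyl (a 2.2-fold higher number from compound 2 to compound 3 (0.35 log units; beyond the scatter)). Measured against 4-fluorophenyl, the loss is now large (a 16-fold higher number from compound 1 to compound 3 (1.22 log units; beyond the scatter)), and compound 1 remains the strongest of the three. Nothing measured here explains this trend. Both substituents differ between compound 2 and compound 3, so the chloro and trifluoromethyl contributions cannot be separated. As far as these compounds go, whether a phenyl ring carrying an amine or a carboxylic acid would be tolerated remains open.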